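Bromo for Methyl on the Core of Compound 3

The source may report more compounds than this note shows. Statements on the series, on what has been measured and on what is new or still open speak of the compounds shown alone.

Measured so far:
compound 1, `Cc1ccc(-c2c(S(=O)(=O)c3ccccc3)cnc3cc(C)nn23)cc1`, 25.2%
compound 2, `O=S(=O)(c1ccccc1)c1cnc2cc(-c3ccc(Cl)cc3)nn2c1-c1ccc(Br)cc1`, 24.7%
compound 3, `Cc1ccc(-c2c(S(=O)(=O)c3ccccc3)cnc3ncnn23)cc1`, 5.2%

In a functional assay on the whole organism for inhibition, with Mus musculus as the target, with a stated time of 2 h, at a dose of 50 mg/kg by the oral route (a lower number here means less inhibition, a higher number more inhibition at the dose given (going by the name of the read-out)), compound 3 gives 5.2%, the lowest of the three numbers. The nearest is compound 2 at 24.7%, and the furthest compound 1 at 25.2%; both gaps lie beyond the usual scatter, so compound 3 is the least inhibiting compound of the set.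

Compound 4, `O=S(=O)(c1ccccc1)c1cnc2ncnn2c1-c1ccc(Br)cc1`, is not yet measured. It differs from compound 3 in one place: bromo in place of methyl on an aromatic carbon. Going by the values given here, no measured pair shows this same change on this core, so no direction can be read from the data. The step is expected to be small, either way, and most likely within the scatter.

Compound 4 is therefore expected to give about 10% in this assay, between 0% and 28%, a step of a number 4.8 percentage points higher from compound 3 to compound 4 (within the scatter).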

Compound 4, a percentage reported as inhibition, in the whole organism at one dose (the size of the read-out at that dose, not a potency): 4.2%
For compound 4 the middle estimate is 5.8 percentage points above the measured one; the range from low to high includes it.
By their numbers in this assay, from the lowest: compounds 4 and 3 (each within the scatter of the next); then compounds 2 and 1 (each within the scatter of the next).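

Read in this assay, the swap from 4-methylphenyl to 4-bromophenyl on the core of compound 3 gives a number 1 percentage points lower from compound 3 to compound 4 (within the scatter) and is the first direct reading of a change at this position. On this core, then, bromo and methyl cannot be told apart at the dose given. No measurement at hand bears on why this is so.

From the compounds shown here alone, whether an amine or a carboxylic acid at this position would move the number remains open. So does whether bromo in place of methyl would behave the same way on the core of compound 1.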